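The source may report more compounds than this note shows. Statements on the series, on what has been measured and on what is new or still open speak of the compounds shown alone.

Measured: compound 1 `N=C(N)NCCC[C@H](NC(=O)[C@@H](CC1CCCCC1)NCC(=O)O)C(=O)NCc1ccc(C(=N)N)cc1`, 470 nM; compound 2 `N=C(N)NCCC[C@H](NC(=O)[C@@H](CC1CCCCC1)NCCC(=O)O)C(=O)NCc1ccc(C(=N)N)cc1`, 2800 nM.

In an assay on isolated protein for inhibition of vitamin K-dependent protein C (Homo sapiens), read by spectrophotometry, with stated times of 300 s and 40 min (a higher number here means a weaker inhibitor, a lower number a stronger inhibitor), compound 1 holds the lower of the two numbers; compound 2 lies a clear step away, a 6.0-fold higher number from compound 1 to compound 2 (0.78 log units; beyond the scatter). Compound 3 `N=C(N)c1ccc(CNC(=O)[C@@H](NC(=O)[C@@H](CC2CCCCC2)NCC(=O)O)C2CCNCC2)cc1` differs from compound 1 by a group of 6 heavy atoms (5 carbon, 1 nitrogen; one six-membered non-aromatic ring with 1 hetero atom) in place of a group of 7 heavy atoms (4 carbon, 3 nitrogen; no ring), on a saturated chain carbon bound to an amide-type nitrogen and a carbonyl carbon. Among the compounds with values here, the one measured step, from compound 1 to compound 2, concerns a different position, the carboxy-bearing chain on the amine nitrogen, and so does not bear directly on this change; no step covers an exchange at the carbon bound to the amide-type nitrogen and carbonyl carbon. Without guidance, a step beyond the scatter in either direction cannot be ruled out, so the expected change from compound 1 to compound 3 is set near zero with a wide range, a 1.9-fold higher number from compound 1 to compound 3 (0.28 log units; within the scatter). The estimate for compound 3 in this assay is 900 nM, with a range of 150 nM to 6000 nM.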

Compound 3, half-maximal inhibitory concentration: 3100 nM
Compound 3: middle estimate off by 3.4-fold (0.54 log units), on the low side, and the stated range covers the measured number.
By their numbers in this assay, from the lowest: compound 1; then compounds 2 and 3 (each within the scatter of the next).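

In this assay, the change on the saturated chain carbon bound to an amide-type nitrogen and a carbonyl carbon, piperidin-4-yl in place of the group of 7 heavy atoms, gives a 6.6-fold higher number from compound 1 to compound 3 (0.82 log units; beyond the scatter). This position is therefore not indifferent to its substituent: this exchange of an open chain with 3 hydrogen-bond donors for a six-membered non-aromatic ring with 1 hydrogen-bond donor moves the number beyond the scatter. No measurement at hand accounts for the step.

Ring, chain and donor count change together here, so the compounds shown do not separate them. Open, as far as these compounds go, is whether a simple amine on a longer chain, such as 4-aminobutyl, or a piperidin-3-yl group at this carbon would stay within the scatter of compound 1.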